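The compounds below may be only part of what the source reports. "The series", "measured", "known", "first", "only" and "open" are said of these compounds alone.

Measured so far, in a functional assay on MCF7 cells (Homo sapiens) for cytotoxicity, read by sulforhodamine B assay, with a stated time of 48 h; a lower number here means a stronger inhibitor, a higher number a weaker inhibitor: compound 1 `O=C(c1cccnc1)c1ccccc1O` gives 24600 nM; compound 2 `O=C(c1cccnc1)c1cccc(Cl)c1O` gives 26700 nM; compound 3 `C=CCOc1ccc(Cl)cc1C(=O)c1cccnc1` gives 54000 nM.

Compound 2 and compound 1 differ by one change, (hydrogen in place of chloro on an aromatic carbon), and that change gave a 1.1-fold lower number from compound 2 to compound 1 (0.04 log units; within the scatter). Compound 3 stands apart; the difference between its core and that of compound 2 is not broken down here. Compound 4 `C=CCOc1ccccc1C(=O)c1cccnc1` is not yet measured. It differs from compound 3 by hydrogen in place of chloro on an aromatic carbon. This is the same kind of change as that from compound 2 to compound 1, though the place differs: there the carbon was ortho to a hydroxy group, here it is para to an allyloxy group. From compound 3 to compound 4 a step of a 1.1-fold lower number from compound 3 to compound 4 (0.03 log units; within the scatter) is expected, resting on the small step from compound 2 to compound 1. In this assay compound 4 is estimated at 50000 nM, expected to fall between 25000 nM and 100000 nM.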

Compound 4, half-maximal inhibitory concentration: > 100000 nM
Compound 4 gave a limit, no number (the forecaster's own chance of this, stated with the estimate: 10%); at least 2.0-fold (0.30 log units) between middle value and limit.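

In this assay compound 4 gives > 100000 nM, which is a limit of the assay and not a number. Hydrogen in place of chloro on an aromatic carbon gave an at least 1.8-fold higher number from compound 3 to compound 4 (0.26 log units; that floor lies within the scatter), so this pair shows neither that the change carries over unaltered from one core to the other nor that its effect depends on the core: the same change on two cores in this assay, a 1.1-fold lower number (0.04 log units; within the scatter) from compound 2 to compound 1 and an at least 1.8-fold higher number (0.26 log units; that floor lies within the scatter) from compound 3 to compound 4; the limit leaves it open whether they differ. Allyl in place of hydrogen on the oxygen on the aromatic ring gave an at least 4.0-fold higher number from compound 1 to compound 4 (0.60 log units; beyond the scatter), but that step rests on a single pair of compounds.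

As far as these compounds go, the true size of both steps from compound 4 remains open. Also open, from the compounds shown here alone, is how the number would move with a methyl group or a longer chain on that oxygen, or with fluoro or bromo in place of the chloro.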